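Replacing the distal aryl ring with an acrylate ester

The compounds below may be only part of what the source reports. "The series", "measured", "known", "first", "only" and "open" are said of these compounds alone.

Compound 1, `COC(=O)/C=C/c1cccc(N(Cc2ccc(-c3cccc(Cl)c3)cc2)C(=O)C2CCCCC2)c1`, was tested in an assay on isolated protein with Bile acid receptor (Homo sapiens) as the target (on this read-out lower numbers stand for an effect already at smaller amounts and higher numbers for an effect only at larger amounts of compound), and gave 94 nM. Among the three measured compounds it holds the highest number, but both its companions lie within the scatter of it: compound 2, `COC(=O)/C=C/c1cccc(N(Cc2ccc(-c3cccc(Cl)c3)cc2)C(=O)C(C)C)c1`, gives 77 nM, and compound 3, `COC(=O)/C=C/c1cccc(N(Cc2ccc(-c3ccc(N(C)C)cc3)cc2)C(=O)C(C)C)c1`, gives 57 nM. The step of a 1.2-fold lower number from compound 1 to compound 2 (0.09 log units; within the scatter) and the step of a 1.4-fold lower number from compound 2 to compound 3 (0.13 log units; within the scatter) are both within the scatter, so the three compounds cannot be told apart on these numbers.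

Compound 4, `CCOC(=O)/C=C/c1ccc(CN(C(=O)C2CCCCC2)c2cccc(/C=C/C(=O)OC)c2)cc1`, differs from compound 1 in one place: 2-(ethoxycarbonyl)ethenyl in place of 3-chlorophenyl on an aromatic carbon. For the measured compounds named here, of the measured steps, only the one from compound 2 to compound 3 touches the same aromatic carbon, and there the exchange of one aryl group for another stayed within the scatter. Going by the values given here, no measured step removes the ring altogether or introduces a 2-(ethoxycarbonyl)ethenyl group, so the present change reaches beyond what the three compounds show. On that basis the expected step of a 1.6-fold higher number from compound 1 to compound 4 (0.20 log units; within the scatter) is a modest move toward a higher number, with wide uncertainty. Compound 4 is therefore estimated at 150 nM, in the range 50 nM to 450 nM.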

Compound 4, half-maximal effective concentration: > 1000 nM
Compound 4: a limit, no number (the forecaster's own chance of this, stated with the estimate: 5%); middle value at least 6.6-fold (0.82 log units) from the limit.
By their numbers in this assay, from the lowest: compounds 3, 2 and 1 (each within the scatter of the next). At a limit, above all of these: compound 4.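

In this assay, putting 2-(ethoxycarbonyl)ethenyl in place of 3-chlorophenyl on the aromatic carbon para to a large group gives an at least 10-fold higher number from compound 1 to compound 4 (1.02 log units; beyond the scatter), the only step shown that lies beyond the scatter. Compound 4 gives > 1000 nM, which is a limit of the assay and not a number: the limit of > 1000 nM in this assay, at which 1 of the 4 values shown sits. The earlier exchange at this carbon kept an aromatic ring, with 4-(dimethylamino)phenyl in place of 3-chlorophenyl, and gave a 1.4-fold lower number from compound 2 to compound 3 (0.13 log units; within the scatter), whereas the present change removes the ring, showing that this position does not accept every group of the same heavy-atom count without a large step.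

The single step removes the ring and brings in the unsaturated ester chain together, so the compounds shown cannot separate what the loss of the aromatic ring contributes from what the entering chain contributes. On these data alone, it also stays open how a carboxylic acid in place of the ethyl ester, a saturated ethyl ester chain, or a pyridine ring at this carbon would read in this assay.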